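The source may report more compounds than this note shows. Statements on the series, on what has been measured and on what is new or still open speak of the compounds shown alone.

Of the compounds shown here, two have been measured in a functional assay on NCI/ADR-RES cells (Homo sapiens) for inhibition, read by sulforhodamine B assay, with a stated time of 48 h, tested at 10 uM; on this read-out lower numbers stand for less inhibition and higher numbers for more inhibition at the one concentration tested (going by the name of the read-out). Compound 1 `c1ccc(-c2cn3ccnc3c(-c3ccc4ncn(C5CCCCC5)c4c3)n2)cc1` carries hydrogen at the position of interest; in this assay compound 1 gives 50.5%. Compound 2 `Clc1ccc(-c2cn3ccnc3c(-c3ccc4ncn(C5CCCCC5)c4c3)n2)cc1` differs only by chloro in place of that hydrogen on an aromatic carbon; in this assay compound 2 gives 11.1%. Among the measured compounds shown here, the single measured step, a number 39.4 percentage points lower from compound 1 to compound 2 (beyond the scatter), leaves compound 2 with the lower of the two numbers, and the gap to compound 1 is beyond the scatter. Compound 3 `Brc1ccc(-c2cn3ccnc3c(-c3ccc4ncn(C5CCCCC5)c4c3)n2)cc1` is the next compound to be tested. Its difference from compound 2 is bromo in place of chloro on an aromatic carbon. For the measured compounds named here, no measured step exchanges one halogen for another, so the chloro-for-hydrogen step from compound 1 to compound 2, large as it was, bears on the new step only loosely: it shows that a change at this carbon can move the number a great deal, but a swap between two halogens is a different kind of change. The expected step is therefore small, a number 3.9 percentage points higher from compound 2 to compound 3 (within the scatter), and likely within the scatter. Compound 3 is estimated at 15%, with a range from 0% to 35%.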

Compound 3, a percentage reported as inhibition, at one concentration (the size of the read-out at that concentration, not a potency): 30.5%
Compound 3: the middle estimate sits 15.5 percentage points below what was measured; the range from low to high includes it.
By their numbers in this assay, from the lowest: compound 2; then compound 3; then compound 1.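

The halogens at this carbon are not interchangeable: in this assay the swap of chloro for bromo gives a number 19.4 percentage points higher from compound 2 to compound 3 (beyond the scatter), so the two groups cannot be treated as one. Set against hydrogen, bromo still gives a number 20 percentage points lower from compound 1 to compound 3 (beyond the scatter), which means that both halogens sit below the unsubstituted compound 1, but the loss with bromo is shallower than the one seen with chloro, which was a number 39.4 percentage points lower from compound 1 to compound 2 (beyond the scatter) in the earlier comparison. Nothing available here accounts for why the two halogens part in this way.

From the compounds shown here alone, the three compounds give a single series at a single carbon, so it remains open where fluoro or iodo would fall relative to chloro and bromo, and whether a group of a different kind there, such as methoxy, an amine or a carboxylic acid, would stay near compound 1 or drop with the halogens. Going by these compounds, each number is also a reading at one concentration, so how these three compounds would compare across a range of concentrations remains open as well.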